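The source may hold more compounds than are shown below. What is called first, only, known or untested is meant among the compounds shown, and "the series" means these compounds.

Measured so far in a functional assay on SGC-7901 cells (Homo sapiens) for antiproliferative activity, read by sulforhodamine B assay, with a stated time of 72 h; on this read-out higher numbers stand for weaker inhibition and lower numbers for stronger inhibition:

- compound 1, `CN(C)C(=S)N/N=C/c1ccc2cccnc2n1`: 630 nM
- compound 2, `S=C(NCc1ccccc1)N/N=C/c1ccc2ccccc2n1`: 53700 nM
- compound 3, `NC(=S)N/N=C/c1nc2ccccc2s1`: a limit, > 100000 nM

Compound 3 sits at the limit of > 100000 nM in this assay, at which 1 of the 3 values shown sits, so its reading is a limit of this assay and not a number. Among the two numbers that remain, compound 2 has the higher one, which on this read-out means the weaker inhibition, and compound 1 lies far below it, beyond the usual scatter. Compound 2 and compound 1 differ in more than one place, so nothing more than this comparison of their two values can be drawn from them.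

The step to be followed leads from compound 2 to compound 4, `Fc1ccc(NC(=S)N/N=C/c2ccc3ccccc3n2)cc1`, which has not yet been measured in this assay. The change is 4-fluorophenyl in place of benzyl on an amide-type nitrogen. The other part of compound 2, the core with its thiocarbonyl, is kept. Among the compounds with values here, no measured pair shows this kind of change, so the expected step rests on little. A modest move toward stronger inhibition is expected, of size a 2.7-fold lower number from compound 2 to compound 4 (0.43 log units; beyond the scatter), but a result that stays within the scatter of compound 2 would not be surprising. Compound 4 is estimated to give 20000 nM, with a range from 3000 nM to 100000 nM.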

Compound 4, half-maximal inhibitory concentration: 32300 nM
Beside the measured number, compound 4's estimate is 1.6-fold (0.21 log units) below it; the measured number falls inside the stated range.
By their numbers in this assay, from the lowest: compound 1; then compounds 4 and 2 (each within the scatter of the next). At a limit, above all of these: compound 3.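

Within the data shown here, this is the first measured change on this amide-type nitrogen, whose other neighbour is the thiocarbonyl carbon, and in this assay it gives a 1.7-fold lower number from compound 2 to compound 4 (0.22 log units; within the scatter), a step within the usual scatter of repeated measurements. The pair therefore shows that, in this assay, 4-fluorophenyl and benzyl cannot be told apart at this place on the shared core, at least for these two groups, which each bring one six-membered aromatic ring of carbon only. Nothing measured here offers an explanation for how close the two readings lie.

Still open, from the compounds shown here alone, is whether a group of a different kind on this same nitrogen, such as a longer alkyl chain or a morpholine ring, would give a reading clearly apart from those of compound 2 and compound 4. Compound 1, at 630 nM, differs from both of them in more than one place, so these compounds cannot say which of its structural differences goes with its much lower number.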